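The source may report more compounds than this note shows. Statements on the series, on what has been measured and on what is new or still open speak of the compounds shown alone.

Working notes on the series. In a functional assay (microsomes, liver) with Rattus norvegicus as the target (on this read-out higher numbers stand for weaker inhibition and lower numbers for stronger inhibition), compound 1 `Cc1c(C)c2c(c(C)c1N)CC(C)(CSc1ccncc1)O2` gives 630 nM, compound 2 `CCCSCC1(C)Cc2c(C)c(N)c(C)c(C)c2O1` gives 280 nM and compound 3 `Cc1c(C)c2c(c(C)c1N)CC(C)(CNc1ccccc1)O2` gives 260 nM. Compound 3 therefore sits level with compound 2, within the scatter, and both stand clear of compound 1.

The next compound is compound 4 `Cc1c(C)c2c(c(C)c1N)CC(C)(CBr)O2`, which has bromo in place of anilino on a saturated chain carbon bound to a saturated ring carbon.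

Two measured steps change the same anilino group. The step of a 2.4-fold lower number from compound 1 to compound 3 (0.38 log units; beyond the scatter) is modest, while the step of a 1.1-fold lower number from compound 2 to compound 3 (0.03 log units; within the scatter) stays within the scatter. The step of a 2.3-fold lower number from compound 1 to compound 2 (0.35 log units; beyond the scatter) is also modest and shows a similar range for a change on the sulfur. Across these three compounds, changes to the side chain have moved the number in this assay only modestly. For the measured compounds named here, none of them carries a lone halogen, however, so the data offer no direct precedent for bromo.

No large move is therefore expected, and a step within the scatter is the likeliest outcome, with a slight lean towards a higher number. The expected step is a 1.5-fold higher number from compound 3 to compound 4 (0.16 log units; within the scatter). The estimate for compound 4 is 380 nM, with an expected range from 170 nM to 850 nM.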

Compound 4, half-maximal inhibitory concentration: 300 nM
Beside the measured number, compound 4's estimate is 1.3-fold (0.10 log units) above it; measured number inside the range.
By their numbers in this assay, from the lowest: compounds 3, 2 and 4 (each within the scatter of the next); then compound 1.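

In this assay, a lone bromo on a saturated chain carbon bound to a saturated ring carbon reads level with the two side chains it is compared with: a 1.2-fold higher number from compound 3 to compound 4 (0.06 log units; within the scatter) and a 1.1-fold higher number from compound 2 to compound 4 (0.03 log units; within the scatter) both stay within the scatter, so among these compounds neither the six-membered aromatic ring of anilino nor the propylsulfanyl chain is needed at this place for a number of this size. For the compounds shown here, compound 1 is the one compound that goes against this level reading, and bromo repeats the modest gap already seen with the other two groups, with a 2.1-fold lower number from compound 1 to compound 4 (0.32 log units; beyond the scatter) lying beyond the scatter. No measurement at hand accounts for why these three groups read alike or why compound 1 stands apart.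

The compounds shown leave open whether the level reading at this place extends to a primary amine, a carboxylic acid or a smaller halogen such as chloro on the same chain carbon. They also leave open whether a phenylsulfanyl group would read with compound 1 or with compounds 2, 3 and 4.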